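The source may hold more compounds than are shown below. What is called first, only, known or untested is meant among the compounds shown, and "the series" means these compounds.

In a functional assay on MT4 cells (Homo sapiens) for cytotoxicity (on this read-out higher numbers stand for weaker inhibition and lower numbers for stronger inhibition), compound 3 `N#Cc1c(N)cccc1S(=O)(=O)c1cccc(Cl)c1` gives only a limit, > 200000 nM. Compound 2 `CCCCOc1cc(C)cc(S(=O)(=O)c2cccc(N)c2C#N)c1` also gives only a limit, > 2000 nM. Compound 1 `Cc1cc(O)cc(S(=O)(=O)c2cccc(N)c2C#N)c1` alone gives a number, 167000 nM. Compound 4 `Cc1cc(Cl)cc(S(=O)(=O)c2cccc(N)c2C#N)c1` differs from compound 3 by methyl in place of hydrogen on an aromatic carbon. Among the compounds with values here, the only measured step, a step that the limit leaves unreadable from compound 1 to compound 2, concerns a different change and has no readable size, so no measured step sizes this one. Compound 1 also carries a methyl on that ring and reads 167000 nM, so a large change in this assay is not expected. The estimated change is an at least 1.3-fold lower number from compound 3 to compound 4 (0.12 log units; that floor lies within the scatter), a small shift toward lower numbers, if any. For compound 4 the expected value is 150000 nM, with an estimated range of 40000 nM to 300000 nM.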

Compound 4, half-maximal inhibitory concentration: > 200000 nM
Compound 4: no number, only a limit; the forecaster's own chance of this, stated with the estimate: 65%; middle value at least 1.3-fold (0.12 log units) from the limit.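

In this assay, methyl in place of hydrogen on this aromatic carbon leaves compound 4 at a limit, with no number, so the change shows no readable gain in inhibition, and the steps to compound 4 from compound 3 and from compound 2 cannot be read: the limit of > 200000 nM in this assay, at which 2 of the 4 values shown sit.

Chloro in place of hydroxy gives the only readable step, an at least 1.1-fold higher number from compound 1 to compound 4 (0.07 log units; that floor lies within the scatter), which sets a floor and not a size.

The compounds shown leave open how far compound 4 lies past its limit, and whether an amine or a carboxylic acid in place of the chloro group would give a number in this assay.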